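Working notes: benzyl arm in place of amide arm

A few compounds are considered here, and "the series" means these few. Any claim that something is new, unique, unknown or untested is made for them only; others in the source may bear on it.

Measured so far in a functional assay on MDA-MB-231 cells (Homo sapiens) for inhibition, read by MTT assay, with a stated time of 48 h; a lower number here means a stronger inhibitor, a higher number a weaker inhibitor:
- compound 1 `COc1ccc(-c2nc3cc(/C=C4\SC(=O)N(CC(=O)N5CCOCC5)C4=O)ccc3[nH]2)cc1OC`; in this assay compound 1 gives > 50000 nM, a limit of the assay.
- compound 2 `COc1cc(-c2nc3cc(/C=C4\SC(=O)N(CC(=O)N5CCCCC5)C4=O)ccc3[nH]2)cc(OC)c1OC`; in this assay compound 2 gives 34900 nM.
- compound 3 `COc1cc(OC)c(-c2nc3cc(/C=C4\SC(=O)N(CC(=O)N5CCCCC5)C4=O)ccc3[nH]2)cc1OC`; in this assay compound 3 gives > 50000 nM, a limit of the assay.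

Going by the values given here, compound 2 is the only member of the series with a number rather than a limit; the other two sit at the limit of > 50000 nM in this assay, at which 2 of the 3 values shown sit. Among the compounds with values here, the single one-place step measured, an at least 1.4-fold higher number from compound 2 to compound 3 (0.15 log units; that floor lies within the scatter), rests on a limit at one end and does not reach beyond the scatter, so it gives no direction.

Compound 4 `COc1cc(-c2nc3cc(/C=C4\SC(=O)N(Cc5cccc(C)c5)C4=O)ccc3[nH]2)cc(OC)c1OC` differs from compound 2 by 3-methylphenyl in place of (piperidin-1-yl)carbonyl on a saturated chain carbon bound to an amide-type nitrogen in a ring; cut one bond further out, the change reads ((piperidin-1-yl)carbonyl)methyl to 3-methylbenzyl. Within the data shown here, no measured step touches this arm: the step from compound 2 to compound 3 alters the trimethoxyphenyl pattern only, and compound 1 keeps an amide arm while sitting at a limit. With nothing to point either way, the expected step in this assay is a 1.0-fold higher number from compound 2 to compound 4 (0.00 log units; within the scatter), that is, none beyond the scatter. Compound 4 is therefore estimated at 35000 nM, in the range 10000 nM to 120000 nM, with a fair chance that only a limit is reported.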

Compound 4, half-maximal inhibitory concentration: 3260 nM
For compound 4 the middle estimate is 11-fold (1.03 log units) above the measured one, outside the stated range (below it).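

In this assay the change from ((piperidin-1-yl)carbonyl)methyl to 3-methylbenzyl gives an 11-fold lower number from compound 2 to compound 4 (1.03 log units; beyond the scatter), with the 3,4,5-trimethoxyphenyl group held fixed, so the arm on the amide-type nitrogen in a ring is a place where the read-out moves. Going by these compounds alone, this is the first step that can be read for direction, and it runs towards the stronger inhibitor; the (piperidin-1-yl)carbonyl group is not needed for a measurable number, as the all-carbon 3-methylphenyl group of compound 4 gives one. Compound 4 also lies well clear of the assay limit, which marks the top of the range of values for this series: the limit of > 50000 nM in this assay, at which 2 of the 4 values shown sit.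

Still open, from the compounds shown here alone, is whether the lower number belongs to the benzyl arm as such or to its methyl group, a question that a plain benzyl arm or a chlorobenzyl arm would settle. Also open, going by these compounds, is whether the 3-methylbenzyl arm keeps its effect when paired with the 2,4,5-trimethoxyphenyl group of compound 3, and whether an arm ending in a carboxylic acid or a basic amine behaves like the amide arm or like the benzyl arm.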